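A few compounds are considered here, and "the series" means these few. Any claim that something is new, unique, unknown or untested is made for them only; others in the source may bear on it.

Of the compounds shown here, three from one series have been measured in an assay for inhibition of serine/threonine-protein kinase PLK2 (Homo sapiens), read by FRET and Z'-LYTE, with a stated time of 1 h; a lower number here means a stronger inhibitor, a higher number a weaker inhibitor. Compound 1 `CC[C@@H]1C(=O)N(C)c2cnc(Nc3ccc(S(=O)(=O)NC)cc3)nc2N1C1CCCC1` gives 3.4 nM, compound 2 `CCCCNS(=O)(=O)c1ccc(Nc2ncc3c(n2)N(C2CCCC2)[C@H](CC)C(=O)N3C)cc1` gives 19.9 nM, and compound 3 `CC[C@@H]1C(=O)N(C)c2cnc(Nc3ccc(S(=O)(=O)Nc4ccccc4)cc3)nc2N1C1CCCC1` gives 54.4 nM. Compound 3 therefore carries the highest number of the three: the step of a 16-fold higher number from compound 1 to compound 3 (1.20 log units; beyond the scatter) is large, and the step of a 2.7-fold higher number from compound 2 to compound 3 (0.44 log units; beyond the scatter) is modest, so compound 3 is the weakest inhibitor among them in this assay. Between the other two, the step of a 5.9-fold higher number from compound 1 to compound 2 (0.77 log units; beyond the scatter) is modest.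

Compound 4 `CC[C@@H]1C(=O)N(C)c2cnc(Nc3ccc(S(N)(=O)=O)cc3)nc2N1C1CCCC1` differs from compound 3 in one place: hydrogen in place of phenyl on a sulfonamide nitrogen. The measured steps that bear on this change all concern the same sulfonamide nitrogen. Replacing methyl with phenyl there, the step of a 16-fold higher number from compound 1 to compound 3 (1.20 log units; beyond the scatter), raised the number strongly, and replacing butyl with phenyl, the step of a 2.7-fold higher number from compound 2 to compound 3 (0.44 log units; beyond the scatter), raised it modestly, while lengthening the chain from methyl to butyl, the step of a 5.9-fold higher number from compound 1 to compound 2 (0.77 log units; beyond the scatter), raised it modestly as well. Removing the phenyl entirely in favour of hydrogen is expected to reverse most of the large step from compound 1 to compound 3, so a large step downward in this assay is estimated, a 14-fold lower number from compound 3 to compound 4 (1.13 log units; beyond the scatter). Compound 4 is accordingly expected to give about 4 nM in this assay, with a likely range from 1.5 nM to 12 nM.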

Compound 4, half-maximal inhibitory concentration: 10.2 nM
Compound 4: the middle estimate sits 2.6-fold (0.41 log units) below what was measured; the measured number falls inside the stated range.
By their numbers in this assay, from the lowest: compound 1; then compounds 4 and 2 (each within the scatter of the next); then compound 3.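

In this assay, the step of a 5.3-fold lower number from compound 3 to compound 4 (0.73 log units; beyond the scatter) shows that removing the phenyl from the sulfonamide nitrogen recovers much of what compound 3 lost, yet the bare nitrogen does not match methyl, as the step of a 3.0-fold higher number from compound 1 to compound 4 (0.48 log units; beyond the scatter) shows. The step of a 2.0-fold lower number from compound 2 to compound 4 (0.29 log units; within the scatter) lies within the scatter, so hydrogen and butyl on this nitrogen cannot be told apart, and compound 1 now stands apart from both compound 2 and compound 4: the number does not simply rise as the chain grows from hydrogen through methyl to butyl, and compound 1 goes against any such trend. Nothing among the data shown accounts for these differences.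

Going by these compounds, it remains open whether ethyl or propyl on this nitrogen would stay close to methyl or fall back towards butyl, and whether a small ring such as cyclopropyl, or a chain ending in a hydroxyl group, would behave in the same way. On these data alone, it is also open whether a benzyl group, which sets the phenyl one carbon further out, would carry the same cost as the phenyl itself.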